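A few compounds are considered here, and "the series" means these few. Any claim that something is new, unique, unknown or untested is made for them only; others in the source may bear on it.

Measured so far in an assay on isolated protein for inhibition of glutathione S-transferase Mu 2 (Homo sapiens), with a stated time of 10 min; a lower number here means a stronger inhibitor, a higher number a weaker inhibitor:
compound 1 `O=C(CCC(=O)OCCCCCCSc1ccc([N+](=O)[O-])c2nonc12)Nc1ccc(Br)cc1`: 32000 nM
compound 2 `COc1ccc(NC(=O)CCC(=O)OCCCCCCSc2ccc([N+](=O)[O-])c3nonc23)cc1OC`: 360 nM

Among the compounds with values here, compound 2 holds the lower of the two numbers in this assay, the only neighbour being compound 1 with its higher value. Within the data shown here, the one recorded step, an 89-fold lower number from compound 1 to compound 2 (1.95 log units; beyond the scatter), shows that the group on the amide-type nitrogen decides much of the result. Compound 3 `O=C(CCC(=O)N1CCOCC1)OCCCCCCSc1ccc([N+](=O)[O-])c2nonc12` carries morpholin-4-yl in place of (3,4-dimethoxyphenyl)amino on a carbonyl carbon, so the aromatic ring that distinguished compound 2 is gone altogether. That step does not repeat the measured one, but it removes the very group behind the large gain, so a sizeable move upward is expected for compound 3, a 22-fold higher number from compound 2 to compound 3 (1.35 log units; beyond the scatter). Compound 3 is estimated at 8000 nM, between 1500 nM and 40000 nM.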

Compound 3, half-maximal inhibitory concentration: 170 nM
Estimate against measurement, compound 3: 47-fold (1.67 log units) above; measured number outside the range, below it.
By their numbers in this assay, from the lowest: compound 3; then compound 2; then compound 1.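

In this assay, an aromatic ring on this carbonyl carbon is not required for a low number: a 2.1-fold lower number from compound 2 to compound 3 (0.33 log units; beyond the scatter), and the amide hydrogen is absent from morpholin-4-yl as well. Against the 4-bromophenyl amide, a 190-fold lower number from compound 1 to compound 3 (2.27 log units; beyond the scatter), leaving compound 1 alone with a high number among the three. Nothing available here explains either step.

Open, on these data alone, is whether the ring oxygen of morpholin-4-yl matters, which a piperidin-1-yl group at this carbonyl carbon would test. As far as these compounds go, the effect of a free carboxylic acid there, or of a longer chain, also remains unknown.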